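Working notes: aryl ether to benzyl swap at the fused ring

This account rests on a few compounds, and the source may have more. Where it says the series, first, only, none or still open, it means among the compounds named here.

Three compounds of the series carry measurements in an ADME assay on HepG2 cells (Homo sapiens) for cytotoxicity, read by luminescence, CellTiter-Glo and ATP content, with a stated time of 72 h; a lower number here means that less compound is needed, a higher number that more compound is needed for the effect. Compound 1 `COc1ccccc1Oc1ccc2c(NCCCNCc3ccco3)ccnc2c1` gives 6500 nM; compound 2 `COc1ccc(Oc2ccc3c(NCCCNCc4cc(F)ccc4OC)ccnc3c2)cc1` gives 7000 nM; compound 3 `CC(C)Cc1ccc2c(NCCCNCc3ccco3)ccnc2c1` gives 16000 nM. Compound 2 thus stands second highest of the three, within the scatter of compound 1 and clearly beneath compound 3. Going by the values given here, the only single-point step seen so far is a 2.5-fold higher number from compound 1 to compound 3 (0.39 log units; beyond the scatter), where a group without acceptors replaced an aryl ether. Compound 4 `COc1ccc(F)cc1CNCCCNc1ccnc2cc(Cc3cc(C)cc(C)c3)ccc12` differs from compound 2 by 3,5-dimethylbenzyl in place of 4-methoxyphenoxy on an aromatic carbon, again trading a group carrying two acceptors for one carrying none, so a modest rise of similar size is expected in this assay. Compound 4 is therefore estimated to give 13000 nM, with a range from 5500 nM to 30000 nM. The expected step is a 1.9-fold higher number from compound 2 to compound 4 (0.27 log units; within the scatter).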

Compound 4, half-maximal effective concentration: 940 nM
The estimate for compound 4 lay 14-fold (1.14 log units) above the measured number, and the stated range ends above it.
By their numbers in this assay, from the lowest: compound 4; then compounds 1 and 2 (each within the scatter of the next); then compound 3.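

In this assay the change to 3,5-dimethylbenzyl from 4-methoxyphenoxy gives a 7.4-fold lower number from compound 2 to compound 4 (0.87 log units; beyond the scatter) and so runs opposite to a 2.5-fold higher number from compound 1 to compound 3 (0.39 log units; beyond the scatter) at the same aromatic carbon. Losing the acceptors of an aryl ether therefore does not fix the direction of the step at this position, which differs between the two pairs along with the entering group and the side chain. No measurement at hand accounts for the lower number. On these data alone, it remains open whether the two methyl groups matter, as an unsubstituted benzyl would show. A morpholine at this carbon would test a group unlike either kind.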